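From 4-fluorophenyl to 2-chlorophenyl on the shared core

The source may report more compounds than this note shows. Statements on the series, on what has been measured and on what is new or still open speak of the compounds shown alone.

Values so far in an ADME assay on L929 cells (Mus musculus) for cytotoxicity, read by resazurin assay, with a stated time of 96 h (a lower number here means that less compound is tolerated, a higher number that more compound is tolerated), for three compounds:

Compound 1 `NC(=S)N/N=C(\COc1ccccc1)c1ccc(Br)cc1` (54900 nM)
Compound 2 `COc1ccc(OC/C(=N\NC(N)=S)c2ccc(Br)cc2)cc1` (102000 nM)
Compound 3 `NC(=S)N/N=C(\COc1ccc(F)cc1)c1ccc(Br)cc1` (52300 nM)

Compound 3 cannot be told apart from the other two, with a 1.0-fold lower number from compound 1 to compound 3 (0.02 log units; within the scatter) and a 2.0-fold lower number from compound 2 to compound 3 (0.29 log units; within the scatter) on the numbers. Compound 4 `NC(=S)N/N=C(\COc1ccccc1Cl)c1ccc(Br)cc1` has 2-chlorophenyl in place of 4-fluorophenyl on an oxygen on a saturated carbon. Two measured steps bear on this change, since both alter the same aromatic ring: a 1.9-fold higher number from compound 1 to compound 2 (0.27 log units; within the scatter) for methoxy in place of hydrogen, and the fluoro step already shown from compound 1 to compound 3. Both stayed within the scatter. Among the compounds with values here, no measured compound carries 2-chlorophenyl, so this is a cautious extrapolation. In this assay no step beyond the scatter is expected, in either direction. The estimated step is a 1.0-fold lower number from compound 3 to compound 4 (0.02 log units; within the scatter) and no more than that is expected. The expected value for compound 4 is 50000 nM with a range from 25000 nM to 100000 nM expected to hold most repeat measurements.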

Compound 4, half-maximal cytotoxic concentration: 25100 nM
The estimate for compound 4 lay 2.0-fold (0.30 log units) above the measured number; measured number inside the range.
By their numbers in this assay, from the lowest: compound 4; then compounds 3, 1 and 2 (each within the scatter of the next).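

In this assay, a change on the aromatic ring attached through the oxygen moves the number beyond the scatter for the first time among these compounds, with 2-chlorophenyl in place of 4-fluorophenyl (a 2.1-fold lower number from compound 3 to compound 4 (0.32 log units; beyond the scatter)) and chloro in place of hydrogen (a 2.2-fold lower number from compound 1 to compound 4 (0.34 log units; beyond the scatter)). Both steps are modest, but they point the same way: less compound is tolerated with the 2-chlorophenyl group. The methoxy and fluoro steps stayed within the scatter, so the ring is not indifferent to every group it carries, and nothing measured here explains the difference.

The step from 4-fluorophenyl to 2-chlorophenyl changes both the halogen and its place on the ring, and the compounds shown do not separate the two. Going by these compounds, how an amine or a carboxylic acid on this ring would behave also remains open.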